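Isopropyl to sec-butyl on the shared core

The compounds below may be only part of what the source reports. "The series", "measured", "known", "first", "only" and "open" are said of these compounds alone.

Values in a functional assay on RAW264.7 cells (Mus musculus) for inhibition, read by ELISA, with a stated time of 24 h (a lower number here means that less compound is needed, a higher number that more compound is needed for the effect), for the series
- compound 1 `CC/C=C\C[C@H]1C(=O)C=C[C@H]1CC(=O)OCCO` gives 24000 nM
- compound 2 `CC/C=C\C[C@H]1C(=O)C=C[C@H]1CC(=O)OC(C)C` gives 20000 nM
- compound 3 `CC/C=C\C[C@H]1C(=O)C=C[C@H]1CC(=O)OC(C)CC` is not yet measured

Among the measured compounds shown here, the only measured step (a 1.2-fold lower number from compound 1 to compound 2 (0.08 log units; within the scatter)) is isopropyl in place of 2-hydroxyethyl on an oxygen next to a carbonyl group. It lies within the scatter, so compound 2 stands level with compound 1 on these numbers. Compound 3 brings methyl in place of hydrogen on a saturated chain carbon, two bonds along the chain from an oxygen next to a carbonyl group in the form of methyl in place of hydrogen on a saturated chain carbon, two bonds along the chain from an oxygen next to a carbonyl group, turning isopropyl to sec-butyl. For the measured compounds named here, the same group changed in the one measured step, which remains a thin guide. Starting from compound 2 at 20000 nM in this assay no step beyond the scatter is expected. The estimated step (a 1.1-fold lower number from compound 2 to compound 3 (0.05 log units; within the scatter)) is expected to stay small. Expected for compound 3 is 18000 nM (estimated range 9000 nM to 32000 nM).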

Compound 3, half-maximal effective concentration: 22000 nM
Compound 3: the middle estimate sits 1.2-fold (0.09 log units) below what was measured, within the range that was stated.
By their numbers in this assay, from the lowest: compounds 2, 3 and 1 (each within the scatter of the next).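

Methyl in place of hydrogen on a saturated chain carbon, two bonds along the chain from an oxygen next to a carbonyl group, gives a 1.1-fold higher number from compound 2 to compound 3 (0.04 log units; within the scatter) in this assay so extending isopropyl to sec-butyl leaves the reading level at this position. Sec-butyl in place of 2-hydroxyethyl on an oxygen next to a carbonyl group gives a 1.1-fold lower number from compound 1 to compound 3 (0.04 log units; within the scatter) and so a second group on that oxygen, after isopropyl, stands level with 2-hydroxyethyl. No measurement is at hand that would explain this flat reading.

On these data alone, whether a longer chain such as n-hexyl, a benzyl group, a chain carrying an amine or the free carboxylic acid would move the number remains open. Also open, as far as these compounds go, is whether any change on the shared core away from that oxygen would shift the reading.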